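The compounds below may be only part of what the source reports. "The series", "measured", "known", "first", "only" and "open" are said of these compounds alone.

Of the compounds shown here, three have so far been measured in an assay on Ltk cells with metabotropic glutamate receptor 5 (Homo sapiens) as the target, read by fluorescence and calcium flux; a lower number here means a stronger inhibitor, a higher number a weaker inhibitor. Compound 1 `Cc1cccc(NC(=O)c2nc(C)ccc2O)n1` gives 7 nM in this assay. Compound 2 `CCCOc1cccnc1Nc1cccc(C)n1` gives 1600 nM in this assay, and compound 3 `Cc1cccc(Nc2ncccc2OCc2ccccc2)n1` gives 870 nM. Compound 2 thus holds the highest of the three numbers: the gap to compound 1 lies far beyond the scatter, whereas the step of a 1.8-fold lower number from compound 2 to compound 3 (0.26 log units; within the scatter) lies within it.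

Compound 4 `CCNc1cccnc1Nc1cccc(C)n1` has not yet been measured. It differs from compound 2 in one place: ethylamino in place of propoxy on an aromatic carbon. For the measured compounds named here, only one measured step exists, a 1.8-fold lower number from compound 2 to compound 3 (0.26 log units; within the scatter), and it alters the chain beyond the oxygen while leaving the oxygen in place, so it says nothing directly about exchanging that oxygen for a nitrogen. Going by the values given here, compound 1 differs from compound 2 in more than one place, and its value shows only that a much lower number is reachable from this series; it offers no guidance on the present change. Among the compounds with values here, with no step bearing on the exchange, compound 4 is expected to show a step of a 1.1-fold lower number from compound 2 to compound 4 (0.03 log units; within the scatter) that does not exceed the scatter. Compound 4 is therefore estimated at 1500 nM in this assay, within a range from 500 nM to 5000 nM.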

Compound 4, half-maximal inhibitory concentration: 3000 nM
Beside the measured number, compound 4's estimate is 2.0-fold (0.30 log units) below it, within the range that was stated.
By their numbers in this assay, from the lowest: compound 1; then compounds 3, 2 and 4 (each within the scatter of the next, the first and the last beyond it).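

In this assay, the exchange of propoxy for ethylamino on the aromatic carbon two atoms from the ring nitrogen gives a 1.9-fold higher number from compound 2 to compound 4 (0.27 log units; within the scatter) and so leaves the number no further from that of compound 2 than repeated measurements would, even though the atom joining the chain to the ring changes and ethylamino carries a hydrogen-bond donor that propoxy lacks. The earlier step, a 1.8-fold lower number from compound 2 to compound 3 (0.26 log units; within the scatter), altered only the chain beyond the oxygen, so this result adds a view of the joining atom itself: in these two steps from compound 2, neither the chain nor that atom moves the number beyond the scatter. Nothing at hand explains this outcome.

The compounds shown leave open whether a free amine, a carboxylic acid or a longer chain on the nitrogen at this carbon would behave in the same way. They also leave open whether a single exchange on the shared core could bring a number near that of compound 1 at 7 nM, whose structure differs from compound 2 in more than one place.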